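One stereocentre inverted in a weakly cytotoxic pair

The compounds below may be only part of what the source reports. "The series", "measured", "known", "first", "only" and "open" are said of these compounds alone.

Going by the values given here, compound 2 `COc1ccc(C(c2ccc(OC)c(OC)c2)[C@H](C)[C@@H](C)CO)cc1OC` is the only member of the group with a number in a functional assay on HeLa cells (Homo sapiens) for cytotoxicity, read by WST assay, with a stated time of 48 h (on this read-out lower numbers stand for stronger inhibition and higher numbers for weaker inhibition), where compound 2 gives 67000 nM. Its mirror image, compound 1 `COc1ccc(C(c2ccc(OC)c(OC)c2)[C@@H](C)[C@H](C)CO)cc1OC`, reaches only the limit of the assay, giving in this assay > 100000 nM; that is a limit, not a number. The step of an at least 1.4-fold lower number from compound 1 to compound 2 (0.17 log units; that floor lies within the scatter) rests on the limit of > 100000 nM in this assay, at which 1 of the 2 values shown sits, and on (the fact that compounds 1 and 2 differ only in the configuration as drawn), and its size cannot be fixed beyond that floor. Compound 3 `COc1ccc(C(c2ccc(OC)c(OC)c2)[C@H](C)[C@H](C)CO)cc1OC` differs from compound 2 as follows: the two compounds have the same atoms and bonds and differ only in configuration as drawn: 1 of 2 stereo elements differ; a stereocentre at a saturated chain carbon is drawn R in compound 2 and S in compound 3. Only the step from compound 1 to compound 2 bears on this change, and because it is bounded by a limit on one side, as shown by the limit of > 100000 nM in this assay, at which 1 of the 2 values shown sits, no direction can be drawn from it. Compound 3 is therefore expected to remain in the same weak range, with a 1.2-fold higher number from compound 2 to compound 3 (0.08 log units; within the scatter) expected to stay within the scatter. The estimate for compound 3 in this assay is 80000 nM, with a range from 30000 nM to 250000 nM.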

Compound 3, half-maximal inhibitory concentration: > 100000 nM
Compound 3 ended at the assay's limit (the forecaster's own chance of this, stated with the estimate: 50%); at least 1.2-fold (0.09 log units) between middle value and limit.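

In this assay, changing a single stereocentre rather than both gives an at least 1.4-fold higher number from compound 2 to compound 3 (0.17 log units; that floor lies within the scatter), and compound 3 joins compound 1 at the limit of the assay. The change is one of configuration alone: the fact that compounds 2 and 3 differ only in the configuration as drawn. Compound 2 thus remains the only one of the three with a number, but this floor lies within the scatter, so no preference for either configuration at this carbon is established.

The step from compound 1 to compound 3 cannot be read, as both values are limits. The compounds shown leave open how the mirror image of compound 3 would read, and whether an amine or a carboxylic acid in place of the terminal alcohol would bring any of these configurations to a measurable number.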